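A few compounds are considered here, and "the series" means these few. Any claim that something is new, unique, unknown or untested is made for them only; others in the source may bear on it.

Going by the values given here, compound 1 `CCCN1CCN(CCNC(=O)n2c(=O)n(C3CC3)c3ccccc32)CC1` gives 0.41 in a functional assay for agonist activity at 5-hydroxytryptamine receptor 4 (Cavia porcellus) (on this read-out lower numbers stand for smaller maximal responses and higher numbers for larger maximal responses), the lowest of the three numbers known so far. Compound 2 `CCCCN1CCN(CCNC(=O)n2c(=O)n(C3CC3)c3ccccc32)CC1` gives 0.46, and compound 3 `CCCN1CCN(CCNC(=O)n2c(=O)n(C(C)C)c3ccccc32)CC1` gives 0.68. The step a number 0.050 higher from compound 1 to compound 2 (within the scatter) stays within the scatter, whereas a number 0.27 higher from compound 1 to compound 3 (beyond the scatter) is modest but real. Compound 4 `CN1CCN(CCCNC(=O)n2c(=O)n(C3CC3)c3ccccc32)CC1` differs from compound 1 by (4-methylpiperazin-1-yl)methyl in place of 4-propylpiperazin-1-yl on a saturated chain carbon, two bonds along the chain from an amide-type nitrogen. Among the compounds with values here, of the measured steps, only that from compound 1 to compound 2 bears on this change, since it too alters a saturated chain carbon, and it stayed within the scatter; the step to compound 3 concerns the aromatic nitrogen and does not apply. Compound 4 is therefore expected to show a number 0.010 higher from compound 1 to compound 4 (within the scatter), nothing beyond the scatter. The estimate for compound 4 is 0.42, within 0.25 to 0.6.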

Compound 4, intrinsic activity: the largest response reached, as a fraction of the reference agonist's: 0.46
For compound 4 the middle estimate is 0.040 below the measured one; the range from low to high includes it.
By their numbers in this assay, from the lowest: compounds 1, 2 and 4 (each within the scatter of the next); then compound 3.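

In this assay, (4-methylpiperazin-1-yl)methyl in place of 4-propylpiperazin-1-yl gives a number 0.050 higher from compound 1 to compound 4 (within the scatter), so the two groups cannot be told apart on this read-out. Going by these compounds alone, this is the first sign that this position, two bonds along the chain from an amide-type nitrogen, tolerates this exchange of the whole ring-bearing group. Nothing measured here explains this result.

As far as these compounds go, it remains open whether morpholin-4-yl or a longer chain would fare the same at this position. From the compounds shown here alone, it is also open whether (4-methylpiperazin-1-yl)methyl would behave alike with isopropyl on the aromatic nitrogen.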